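The compounds below may be only part of what the source reports. "The series", "measured", "known", "first", "only" and "open" are said of these compounds alone.

Measured in an ADME assay on L6 cells (Rattus norvegicus) for cytotoxicity, with a stated time of 72 h; on this read-out lower numbers stand for stronger inhibition and higher numbers for weaker inhibition:
Compound 1 `CC(=O)OC1CC2(N3CCCCC3)CC(c3ccccc3)C1C(c1ccccc1)C2` gives "not determined" (no result reported)
Compound 2 `OC1CC2(N3CCCC3)CC(c3ccccc3)C1C(c1ccccc1)C2` gives 26800 nM
Compound 3 `CN(C)C12CC(O)C(C(c3ccccc3)C1)C(c1ccccc1)C2` gives 133000 nM

Of the two numbers in this assay, the higher belongs to compound 3 at 133000 nM and compound 1 offers none for comparison. Compound 4 `OC1CC2(N3CCCCC3)CC(c3ccccc3)C1C(c1ccccc1)C2` differs from compound 3 in one place: piperidin-1-yl in place of dimethylamino on a saturated ring carbon. Piperidin-1-yl stands in place of dimethylamino on a saturated ring carbon. For the measured compounds named here, the one measured step that bears on this is a 5.0-fold higher number from compound 2 to compound 3 (0.70 log units; beyond the scatter), which put dimethylamino in place of pyrrolidin-1-yl. Restoring a ring at that carbon therefore leads to the expectation of a lower number of similar modest size, an estimated 4.4-fold lower number from compound 3 to compound 4 (0.65 log units; beyond the scatter). Compound 4 is expected near 30000 nM, with an estimated range of 12000 nM to 75000 nM.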

Compound 4, half-maximal inhibitory concentration: 37300 nM
For compound 4 the middle estimate is 1.2-fold (0.09 log units) below the measured one, and the stated range covers the measured number.
By their numbers in this assay, from the lowest: compounds 2 and 4 (each within the scatter of the next); then compound 3.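

In this assay, piperidin-1-yl in place of dimethylamino on this saturated ring carbon gave a 3.6-fold lower number from compound 3 to compound 4 (0.55 log units; beyond the scatter) as a second ring-bearing comparison with dimethylamino. For the compounds shown here, exchanging one ring for the other gave a 1.4-fold higher number from compound 2 to compound 4 (0.14 log units; within the scatter) and so does not separate pyrrolidin-1-yl from piperidin-1-yl, leaving dimethylamino, the one group here without a ring, apart from both. No evidence is available to explain this difference. The compounds shown leave open whether morpholine or diethylamino at this carbon would fall with the two ring amines or with dimethylamino. Compound 1 reports no number, so its acetate in place of the hydroxy group cannot be judged.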